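Carbonyl aryl replacement on the shared trimethoxyphenyl core

This account rests on a few compounds, and the source may have more. Where it says the series, first, only, none or still open, it means among the compounds named here.

Compound 1 `COc1cc(-c2nnc3n2NC(c2ccco2)C(C(=O)c2cccs2)S3)cc(OC)c1OC` is known in a functional assay on MCF7 cells (Homo sapiens) for cytotoxicity, read by MTT assay, with a stated time of 48 h (on this read-out lower numbers stand for stronger inhibition and higher numbers for weaker inhibition), only as a limit: compound 1 gives > 100000 nM. Compound 2 `COc1cc(-c2nnc3n2NC(c2cccs2)C(C(=O)c2ccccc2)S3)cc(OC)c1OC` likewise reaches only the limit in this assay, where compound 2 gives > 100000 nM. For the measured compounds named here, compound 3 `COc1cc(C(=O)C2Sc3nnc(-c4cc(OC)c(OC)c(OC)c4)n3NC2c2cccs2)cc(OC)c1OC` is the one member of the series with a number, giving 71000 nM in this assay. Going by the values given here, the single step measured in one place, an at least 1.4-fold lower number from compound 2 to compound 3 (0.14 log units; that floor lies within the scatter), changes the aryl on the carbonyl carbon and lies within the scatter; the limit of > 100000 nM in this assay, at which 2 of the 3 values shown sit, marks where most of the series sits.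

Compound 4 `COc1cc(-c2nnc3n2NC(c2ccco2)C(C(=O)c2ccc(F)c(F)c2)S3)cc(OC)c1OC` differs from compound 1 at that same carbonyl carbon: 3,4-difluorophenyl in place of thiophen-2-yl on a carbonyl carbon. Among the compounds with values here, no measured step puts a 3,4-difluorophenyl onto the carbonyl carbon, and the one change at that carbon gave only an at least 1.4-fold lower number from compound 2 to compound 3 (0.14 log units; that floor lies within the scatter), so the carbonyl aryl has so far moved this read-out little. Compound 1 itself offers only a limit, so the step of a number no higher from compound 1 to compound 4 (the limit leaves the size open) is expected to stay small, with no direction beyond the scatter. Compound 4 is therefore expected at 100000 nM in this assay, within 30000 nM to 300000 nM, with a fair chance of again reaching only a limit.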

Compound 4, half-maximal inhibitory concentration: 73200 nM
Estimate against measurement, compound 4: 1.4-fold (0.14 log units) above; low and high end bracket the measured number.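

On the core of compound 1, 3,4-difluorophenyl in place of thiophen-2-yl on the carbonyl carbon yields a number in this assay, whereas compound 1 stands only as a limit. Going by these compounds, the step reads an at least 1.3-fold lower number from compound 1 to compound 4 (0.13 log units; that floor lies within the scatter), so a six-membered aromatic ring of carbon only is tolerated at this carbon without any shift that can be placed beyond the scatter, although the upper size of the step remains unknown. This adds a second step at the carbonyl carbon, on a core carrying a different ring from the one in the earlier step, and again only its floor can be read, which keeps the picture at this position bounded from one side: the limit of > 100000 nM in this assay, at which 2 of the 4 values shown sit.

On these data alone, whether the carbonyl aryl matters at all in this read-out remains open, since neither step at this carbon has a measured number at both ends. Also open, as far as these compounds go, is how the series responds at this carbon to a group of a different kind, such as an aryl bearing an amine or a carboxylic acid, or a longer alkyl chain in place of the aryl.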